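Carboxy added to the amine-bearing chain carbon of compound 3

A few compounds are considered here, and "the series" means these few. Any claim that something is new, unique, unknown or untested is made for them only; others in the source may bear on it.

Compound 1, `CCCCCCCCCCCCN[C@H](CCC(=O)NC(CCCC(N)C(=O)O)C(=O)O)C(=O)O`: 0.023 nM in a functional assay on HEK293 cells for agonist activity at Nucleotide-binding oligomerization domain-containing protein 1 (Homo sapiens), read by spectrophotometry; on this read-out higher numbers stand for an effect only at larger amounts of compound and lower numbers for an effect already at smaller amounts
Compound 2, `CCCCCCCCN(CCCCCCCC)[C@H](CCC(=O)NC(CCCC(N)C(=O)O)C(=O)O)C(=O)O`: 0.2 nM in this assay
Compound 3, `CCCCCCCCCCCC(=O)N[C@H](CCC(=O)NCCCCCN)C(=O)O`: > 100 nM in this assay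

Compound 1 and compound 2 both give sub-nanomolar values in this assay, compound 1 at 0.023 nM and compound 2 at 0.2 nM. Compound 3 stands apart from both: its value in this assay is only a limit of the assay, > 100 nM, and no number is known for it; this is recorded in the limit of > 100 nM in this assay, at which 1 of the 3 values shown sits. Among the measured compounds shown here, no pair among the measured compounds differs in a single place, so no measured step is available to set a scale.

Compound 4, `CCCCCCCCCCCC(=O)N[C@H](CCC(=O)NCCCC[C@@H](N)C(=O)O)C(=O)O`, differs from compound 3 in one place: carboxy in place of hydrogen on a saturated chain carbon bound to an amine nitrogen and a saturated chain carbon. Compound 1 and compound 2, which carry an amino acid bearing such a carboxy, sit far below the limit at which compound 3 sits, so a step toward smaller values is expected for compound 4 in this assay, of size an at least 3.3-fold lower number from compound 3 to compound 4 (0.52 log units; beyond the scatter). With only a limit on compound 3 the size is uncertain; compound 4 is estimated at 30 nM in this assay, within 2 nM to 400 nM.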

Compound 4, half-maximal effective concentration: 0.37 nM
For compound 4 the middle estimate is 81-fold (1.91 log units) above the measured one, and the stated range ends above it.
By their numbers in this assay, from the lowest: compound 1; then compounds 2 and 4 (each within the scatter of the next). At a limit, above all of these: compound 3.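

In this assay, among the compounds shown here, carboxy in place of hydrogen on a saturated chain carbon bound to an amine nitrogen and a saturated chain carbon gives an at least 270-fold lower number from compound 3 to compound 4 (2.43 log units; beyond the scatter), the first step that can be read from a single change, and a large one. Compound 4 gives 0.37 nM with the rest of compound 3 unchanged, including the long acyl chain, so this one carbon is a position at which the read-out responds strongly to substitution. The step is a bound rather than a measured size, since its starting point is only a limit of the assay, held by compound 3: the limit of > 100 nM in this assay, at which 1 of the 4 values shown sits.

Still open, going by these compounds, is whether the carboxylic acid itself is required at this carbon, or whether a primary amide, a hydroxymethyl group or a tetrazole would give a step of similar size. Also open, on these data alone, are the opposite configuration at this carbon and how the step changes when the acyl chain of compound 4 is replaced by a shorter chain or by an alkyl amine.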